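Trimming a branched chain on a furanopyridine-type scaffold's amino group

This account rests on a few compounds, and the source may have more. Where it says the series, first, only, none or still open, it means among the compounds named here.

Of the compounds shown here, three built on a shared core have been tested in a functional assay on HEK293 cells for agonist activity at Toll-like receptor 8 (Homo sapiens), read by reporter gene assay; on this read-out higher numbers stand for an effect only at larger amounts of compound and lower numbers for an effect already at smaller amounts. Compound 1, `CCCCCNc1oc2c(C)ncc(CO)c2c1Nc1cccc([N+](=O)[O-])c1`, carries a pentyl chain on its amino nitrogen and gives 850 nM. Compound 2, `Cc1ncc(CO)c2c(Nc3ccccc3)c(NCc3ccccc3)oc12`, bears a benzyl group there and gives 1680 nM. Compound 3, `CCCC(C)Nc1oc2c(C)ncc(CO)c2c1Nc1ccccn1`, combines a 1-methylbutyl chain with a pyridinylamino group and gives 9010 nM, the highest of the three numbers; its gaps to compound 2 and to compound 1 both lie beyond the usual scatter, so compound 3 needs the largest amount of the three to act.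

Compound 4, `Cc1ncc(CO)c2c(Nc3ccccn3)c(NC(C)(C)C)oc12`, is the next compound to be measured. It differs from compound 3 in one place: tert-butyl in place of 1-methylbutyl on a nitrogen on an aromatic ring. Within the data shown here, no step between two measured compounds of this set matches that change, so nothing here shows what it does. With the pyridinylamino group kept, the branched chain merely loses one carbon and becomes more compact; the expected step from compound 3 to compound 4 in this assay is therefore small, a 1.3-fold higher number from compound 3 to compound 4 (0.12 log units; within the scatter), leaning toward a slightly weaker effect. Compound 4 is estimated to give 12000 nM, within 4000 nM to 40000 nM.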

Compound 4, half-maximal effective concentration: "not active" (no number reported)
The entry for compound 4 holds no number, so the estimate cannot be set against anything.
By their numbers in this assay, from the lowest: compounds 1 and 2 (each within the scatter of the next); then compound 3.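

Among these compounds, compound 4 is recorded in this assay as "not active", without a number, so no step from compound 3 can be read. Nothing shown here explains this result. The compounds shown leave open how far tert-butyl in place of 1-methylbutyl shifts the number.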